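Lengthening the Chain of Compound 3

The source may hold more compounds than are shown below. What is called first, only, known or untested is meant among the compounds shown, and "the series" means these compounds.

In a functional assay on EC9706 cells (Homo sapiens) for antiproliferative activity, read by MTT assay, with a stated time of 48 h (on this read-out higher numbers stand for weaker inhibition and lower numbers for stronger inhibition), compound 3 (`CCCCCCCCCn1cc(COC[C@@H]2OC[C@H](N)[C@H]2O)nn1`) gives > 128000 nM, which is a limit of the assay and not a number. Compound 2 (`CCCCCCCCn1cc(COC[C@@H]2OC[C@H](N)[C@H]2O)nn1`) gives > 128000 nM, also a limit. Compound 3 therefore stands at the limit of > 128000 nM in this assay, at which 2 of the 3 values shown sit. Among the compounds with values here, the one measured step on this series is a step that the two limits leave unreadable from compound 2 to compound 3, so it offers no size to carry forward.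

Compound 4 (`CCCCCCCCCCCCn1cc(COC[C@@H]2OC[C@H](N)[C@H]2O)nn1`) differs from compound 3 by propyl in place of hydrogen on a saturated chain carbon, nine bonds along the chain from an aromatic nitrogen. The nearest guide is compound 1 (`CCCCCCCCCCCCn1cc(COC[C@@H]2OC[C@H](N)[C@@H]2O)nn1`), which bears the same chain as compound 4 on a core of different spatial arrangement, and compound 1 gives a true number of 16000 nM in this assay. On that single value, a clear move toward stronger inhibition is expected, though the arrangement of the core may matter and compound 4 could still stay at the limit. The expected change is an at least 4.2-fold lower number from compound 3 to compound 4 (0.63 log units; beyond the scatter). For compound 4 the estimated value is 30000 nM, within an expected range from 9000 nM to 110000 nM.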

Compound 4, half-maximal inhibitory concentration: 93800 nM
For compound 4 the middle estimate is 3.1-fold (0.50 log units) below the measured one, within the range that was stated.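

With propyl in place of hydrogen at this position, compound 4 gives a true number in this assay on a core arrangement whose other two members sit at a limit of the assay: the limit of > 128000 nM in this assay, at which 2 of the 4 values shown sit. Those limits allow only floors for the change, an at least 1.3-fold lower number from compound 3 to compound 4 (0.13 log units; that floor lies within the scatter) and an at least 1.3-fold lower number from compound 2 to compound 4 (0.13 log units; that floor lies within the scatter), so its true size stays unfixed. The stereocentre matters more clearly, with a 5.9-fold higher number from compound 1 to compound 4 (0.77 log units; beyond the scatter), and this comparison isolates the drawn configuration: the fact that compounds 1 and 4 differ only in the configuration as drawn.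

The compounds shown leave open whether this gap between configurations holds for any other chain, since only this one chain appears in both forms. They also leave open whether a longer chain would lower the number further on either core.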